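The compounds below may be only part of what the source reports. "The series", "measured", "known", "first", "only" and "open" are said of these compounds alone.

All three measured compounds share one core. In a functional assay on HepG2 cells (Homo sapiens) for antiproliferative activity, read by MTT assay, with a stated time of 24 h (on this read-out lower numbers stand for stronger inhibition and higher numbers for weaker inhibition), compound 1 `COC(=O)c1scc(-c2ccc(NC(=O)c3ccccn3)cc2)c1OC` gives 10300 nM while compound 2 `COC(=O)c1scc(-c2ccc(NC(=O)c3cccc(C(F)(F)F)c3)cc2)c1OC` gives 32500 nM and compound 3 `COC(=O)c1scc(-c2ccc(NC(=O)c3cccc(I)c3)cc2)c1OC` gives 16500 nM on the same read-out. Compound 3 cannot be separated from either of the others: a 1.6-fold higher number from compound 1 to compound 3 (0.20 log units; within the scatter) and a 2.0-fold lower number from compound 2 to compound 3 (0.29 log units; within the scatter) both lie within the scatter, while a 3.2-fold higher number from compound 1 to compound 2 (0.50 log units; beyond the scatter) is a modest step beyond it.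

Compound 4 `COC(=O)c1scc(-c2ccc(NC(=O)c3ccc(OC)nc3)cc2)c1OC` has not yet been measured. It carries 6-methoxypyridin-3-yl in place of 3-iodophenyl on a carbonyl carbon, and the count runs 6-methoxypyridin-3-yl in place of 3-iodophenyl on a carbonyl carbon for this change. Among the measured compounds shown here, no measured compound carries this exact group, so the evidence is indirect. The nearest guide is compound 1 with its pyridin-2-yl, where the swap to 3-iodophenyl gave a 1.6-fold higher number from compound 1 to compound 3 (0.20 log units; within the scatter) and stayed within the scatter. No step beyond the scatter is therefore expected in this assay here. The expected step is a 1.2-fold lower number from compound 3 to compound 4 (0.07 log units; within the scatter) and would remain within the scatter. For compound 4 the estimate is 14000 nM with an expected range from 6000 nM to 35000 nM in this assay.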

Compound 4, half-maximal inhibitory concentration: > 50000 nM
Compound 4 ended at the assay's limit; the forecaster's own chance of this, stated with the estimate: 8%; middle value at least 3.5-fold (0.55 log units) away from the limit.
By their numbers in this assay, from the lowest: compounds 1, 3 and 2 (each within the scatter of the next, the first and the last beyond it). At a limit, above all of these: compound 4.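

In this assay compound 4 sits at a limit of the assay rather than at a number: the limit of > 50000 nM in this assay, at which 1 of the 4 values shown sits. The earlier groups on this carbonyl carbon gave only small or modest steps, but this change shows that the place can respond more strongly, with an at least 3.0-fold higher number from compound 3 to compound 4 (0.48 log units; beyond the scatter) and an at least 4.8-fold higher number from compound 1 to compound 4 (0.68 log units; beyond the scatter), and the pyridine-type ring of compound 1 evidently does not carry over its number to every ring with a nitrogen. The remaining step, an at least 1.5-fold higher number from compound 2 to compound 4 (0.18 log units; that floor lies within the scatter), separates nothing on its own.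

The compounds shown leave open whether the shift goes with the methoxy group or with the point of attachment on the pyridine ring, as the two change together here. A plain pyridin-3-yl, or a 6-aminopyridin-3-yl with an amine in place of the methoxy, would help to pull these apart.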